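Chloro in place of hydrogen on the benzylidene ring

This account rests on a few compounds, and the source may have more. Where it says the series, first, only, none or still open, it means among the compounds named here.

Of the compounds shown here, two of a shared core have been tested in a functional assay on the whole organism (strain albino) for inhibition, with Rattus norvegicus as the target, read by paw edema, with stated times of 1 h and 3 h, at a dose of 25 mg/kg by the oral route; on this read-out higher numbers stand for more inhibition at the one dose given (going by the name of the read-out) and lower numbers for less inhibition. Compound 2 `CC1=C(C(=O)Nc2ccc(F)cc2)C(c2ccc(Cl)cc2)n2c(s/c(=C/c3ccccc3Cl)c2=O)=N1` gives 16% in this assay. Compound 1 `CC1=C(C(=O)Nc2ccc(F)cc2)C(c2ccc(Br)cc2)n2c(s/c(=C/c3ccc(Cl)cc3Cl)c2=O)=N1` gives 14% in this assay, and the two numbers sit within the usual scatter of each other, so neither can be set apart from the other. Among the compounds with values here, no single-point step between measured compounds is available from these two.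

Compound 3 `CC1=C(C(=O)Nc2ccc(F)cc2)C(c2ccc(Cl)cc2)n2c(s/c(=C/c3ccc(Cl)cc3Cl)c2=O)=N1` has not yet been measured in this assay. It differs from compound 2 in one place: chloro in place of hydrogen on an aromatic carbon. Within the data shown here, with no measured step of this kind to lean on and both known values close together, the expected step from compound 2 to compound 3 is a number 1 percentage points lower from compound 2 to compound 3 (within the scatter), that is, nothing beyond the scatter. Compound 3 is therefore estimated to give 15% in this assay, within a range from 5% to 28%.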

Compound 3, a percentage reported as inhibition, in the whole organism at one dose (the size of the read-out at that dose, not a potency): 14%
The estimate for compound 3 lay 1 percentage points above the measured number, and the stated range covers the measured number.
By their numbers in this assay, from the lowest: compounds 1, 3 and 2 (each within the scatter of the next).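

Where the earlier compounds offered no single-place step, the 2-chlorophenyl to 2,4-dichlorophenyl difference now gives one in this assay: a number 2 percentage points lower from compound 2 to compound 3 (within the scatter). Chloro in place of bromo on an aromatic carbon gives a second step, no change at the digits printed from compound 1 to compound 3 (within the scatter), so neither single change separates its pair of compounds on this read-out at the one dose given. No measurement available here offers an explanation for how closely these numbers sit together.

The compounds shown say nothing about how a methoxy group or an amine on this carbon, para to the large group, would read in this assay. They also leave open whether either change would separate its pair at a different dose, since all three numbers come from a single dose.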